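The compounds below may be only part of what the source reports. "The series", "measured", "known", "first", "only" and "open" are said of these compounds alone.

In a functional assay on PC-3 cells (Homo sapiens) for cytotoxicity, read by MTT assay, with a stated time of 48 h (on this read-out higher numbers stand for weaker inhibition and lower numbers for stronger inhibition), compound 1 `COc1ccc(OC)c(/C=C/C(=O)/C=C/c2cc3ccccc3nc2Oc2cccc(Cl)c2)c1` reads > 10000 nM as a limit. Compound 2 `COc1ccc(/C=C/C(=O)/C=C/c2cc3ccccc3nc2Oc2cccc(Cl)c2)cc1OC` reads > 10000 nM as a limit too. Compound 3 `COc1cc(OC)c(OC)cc1/C=C/C(=O)/C=C/c1cc2ccccc2nc1Oc1cccc(Cl)c1` reads > 10000 nM and this is likewise a limit, not a number. The series therefore stands at the limit of > 10000 nM in this assay, at which 3 of the 3 values shown sit, and offers no ranking.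

Compound 4 `COc1cc(OC)c(/C=C/C(=O)/C=C/c2cc3ccccc3nc2Oc2cccc(Cl)c2)c(OC)c1` has 2,4,6-trimethoxyphenyl in place of 2,4,5-trimethoxyphenyl on a double-bonded chain carbon bound to a double-bonded chain carbon with the same atoms joined differently. The nearest change in kind is a step that the two limits leave unreadable from compound 1 to compound 2 which also exchanges one dimethoxyphenyl pattern for another. Since a step that the two limits leave unreadable from compound 1 to compound 3 and a step that the two limits leave unreadable from compound 2 to compound 3 also have no readable size, no step beyond the scatter is expected in this assay and no direction can be given. The estimated move, a step that the limit leaves unreadable from compound 3 to compound 4, is accordingly expected to be small. For compound 4 the expected value is 12000 nM with an estimated range from 4000 nM to 40000 nM as the likely span.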

Compound 4, half-maximal inhibitory concentration: > 10000 nM
Compound 4: only a limit was reported; the forecaster's own chance of this, stated with the estimate: 75%; the middle value is on the limit's open side.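

Compound 4 gives no readable step to compound 1, compound 2 or compound 3, as all four stand at one limit, which is not a number: the limit of > 10000 nM in this assay, at which 4 of the 4 values shown sit.

The compounds shown leave open whether these methoxyphenyl patterns differ at all, and what actual value each compound has.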